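The compounds below may be only part of what the source reports. "The series", "measured", "known", "first", "only" and "open" are said of these compounds alone.

compound 1 `CCc1ccc(SCc2ccc(/C=C/C(=O)Nc3ccccc3N)cc2)cc1` gives 60.7%
compound 2 `CCc1ccc(SCc2ccc(C(=O)Nc3ccccc3N)cc2)cc1` gives 53.6%
compound 3 `CC(C)(C)c1ccc(SCc2ccc(/C=C/C(=O)Nc3ccccc3N)cc2)cc1` gives 71.5%

In a functional assay on A549 cells (Homo sapiens) for inhibition, read by CCK-8 assay, with a stated time of 72 h, tested at 2 uM (on this read-out higher numbers stand for more inhibition of growth at the one concentration tested and lower numbers for less inhibition of growth), compound 2 gives 53.6% which lies within the scatter of compound 1 and beyond the scatter under compound 3. Compound 4 `Cc1cc(C)cc(SCc2ccc(C(=O)Nc3ccccc3N)cc2)c1` carries 3,5-dimethylphenyl in place of 4-ethylphenyl on a sulfur and the atoms stay the same. Within the data shown here, one measured step bears on this group, and only loosely: a number 10.8 percentage points higher from compound 1 to compound 3 (beyond the scatter) is modest, comes from a different change, and stands on the core of compound 1. It offers a scale but no direction. The expected step is a number 1.4 percentage points higher from compound 2 to compound 4 (within the scatter) and it is not expected to exceed the scatter. Compound 4 is estimated at 55% with an expected range from 41% to 69% in this read-out.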

Compound 4, percent growth inhibition at one concentration: 33.3%
Estimate against measurement, compound 4: 21.7 percentage points above, outside the stated range (below it).
By their numbers in this assay, from the lowest: compound 4; then compounds 2 and 1 (each within the scatter of the next); then compound 3.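

In this assay, the group on the sulfur turns out to matter on the shared core: 3,5-dimethylphenyl in place of 4-ethylphenyl, with the same atoms joined differently, gives a number 20.3 percentage points lower from compound 2 to compound 4 (beyond the scatter). Among these compounds, the only earlier step at this group raised the number, so this is the first sign that a change here can also lower it. No measurement on these compounds accounts for the loss. Open, as far as these compounds go, is how a plain phenyl or a methoxyphenyl on the sulfur would read, and whether 3,5-dimethylphenyl on the core of compound 1 would also fall.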